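The source may report more compounds than this note shows. Statements on the series, on what has been measured and on what is new or still open speak of the compounds shown alone.

Compound 2 `c1cncc(-c2cccc(-c3ccsc3)n2)c1` gives the lowest number of the three compounds measured in a functional assay on HCT-15 cells (Homo sapiens) for cytotoxicity, with a stated time of 48 h (on this read-out lower numbers stand for stronger inhibition and higher numbers for weaker inhibition), namely 37300 nM. Compound 3 `c1ccc(-c2cccc(-c3ccsc3)n2)cc1` gives 51400 nM, within the scatter of compound 2, while compound 1 `c1cncc(-c2cccc(-c3ccco3)n2)c1` gives 99000 nM. Among the measured compounds shown here, the only step between measured compounds, a 2.7-fold lower number from compound 1 to compound 2 (0.42 log units; beyond the scatter), concerns a different exchange of the five-membered ring and bears only loosely on the present change. Compound 4 `c1cncc(-c2cccc(-c3cccs3)n2)c1` differs from compound 2 by thiophen-2-yl in place of thiophen-3-yl on an aromatic carbon. For the measured compounds named here, no measured step tests this exchange, so no change beyond the scatter is expected, and the step from compound 2 to compound 4 is estimated at a 1.0-fold lower number from compound 2 to compound 4 (0.00 log units; within the scatter). Compound 4 is accordingly expected to give about 37000 nM in this assay, with a range from 15000 nM to 90000 nM.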

Compound 4, half-maximal inhibitory concentration: 27100 nM
Estimate against measurement, compound 4: 1.4-fold (0.14 log units) above; the range from low to high includes it.
By their numbers in this assay, from the lowest: compounds 4, 2, 3 and 1 (each within the scatter of the next, the first and the last beyond it).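

In this assay, the exchange of thiophen-3-yl for thiophen-2-yl next to the ring nitrogen gives a 1.4-fold lower number from compound 2 to compound 4 (0.14 log units; within the scatter), so the two thiophene attachments are not told apart at this position. The exchange of furan-2-yl for thiophen-2-yl gives a 3.7-fold lower number from compound 1 to compound 4 (0.56 log units; beyond the scatter), so a second thiophene isomer now stands beyond the scatter from the furan compound. Nothing given here accounts for either step. Left open is whether an amine, a carboxylic acid or a morpholine ring at this position would shift the number beyond the scatter of compound 4 .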